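The compounds below may be only part of what the source reports. "The series", "measured", "known", "first", "only" and "open" are said of these compounds alone.

Measured in a functional assay on Bel-7402 cells (Homo sapiens) for inhibition, read by MTT assay, with a stated time of 24 h, tested at 1 ug/mL; on this read-out higher numbers stand for more inhibition of growth at the one concentration tested and lower numbers for less inhibition of growth:
Compound 1 `O=C(CCCCC(S)CCS)NO`: 9.12%
Compound 2 `O=C(CCCCC1CCSS1)Nc1ccc(Cl)cn1`: 7.44%
Compound 3 `O=C(CCCCC(S)CCS)Nc1ccccn1`: "not active" (no number reported)

Compound 3 has no single number: in this assay compound 3 was reported as "not active" (no number reported) and cannot be placed by size beside the other two. Compound 4 `O=C(CCCCC(S)CCS)Nc1ccc(Cl)cn1` differs from it in one place. The change is chloro in place of hydrogen on an aromatic carbon and in words it is chloro in place of hydrogen on an aromatic carbon. Among the compounds with values here, no measured pair shows this change alone. Within the data shown here, the only measured compound carrying that chloro, compound 2, gives 7.44% in this assay and this is a low reading. No step beyond the usual scatter is therefore expected, and any small shift should be upward. For compound 4 the estimated value is 7% with an expected range from 0% to 18% here.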

Compound 4, percent growth inhibition at one concentration: 2.34%
Compound 4: middle estimate off by 4.7 percentage points, on the high side; the range from low to high includes it.
By their numbers in this assay, from the lowest: compounds 4, 2 and 1 (each within the scatter of the next).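

In this assay compound 4, with chloro on an aromatic carbon para to a large group, gives 2.34% as a number, whereas compound 3 has none, so the size of this change cannot be read. With that chloro in place, the open chain in place of the five-membered ring gives a number 5.1 percentage points lower from compound 2 to compound 4 (within the scatter), so these two forms cannot be told apart here. No measurement shown explains these readings.

Going by these compounds, whether bromo, methyl or methoxy at this position would give a reading clearly beyond the scatter stays open, as does the effect of a longer chain.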